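The source may hold more compounds than are shown below. What is called first, only, known or untested is meant among the compounds shown, and "the series" means these compounds.

Series values in an ADME assay on MRC5 cells (Homo sapiens) for inhibition, with a stated time of 72 h (a higher number here means that more compound is needed for the effect, a lower number that less compound is needed), each one a limit of the assay and not a number:

- Compound 1 `COc1cccc(OC)c1C(=O)Nc1c[nH]nc1C(=O)NC1CC1`: > 50000 nM.
- Compound 2 `COc1cccc(OC)c1C(=O)Nc1c[nH]nc1C(=O)NN1CCOCC1`: > 50000 nM.
- Compound 3 `COc1cccc(OC)c1C(=O)Nc1c[nH]nc1C(=O)NCc1ccccn1`: > 50000 nM.

Compound 3 has no numerical value and shares its position with compound 1 and compound 2, as shown by the limit of > 50000 nM in this assay, at which 3 of the 3 values shown sit.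

The next change leads to compound 4 `COc1cccc(OC)c1C(=O)Nc1c[nH]nc1C(=O)NCCN1CCCC1`, with (pyrrolidin-1-yl)methyl in place of pyridin-2-yl on a saturated chain carbon bound to an amide-type nitrogen.

For the measured compounds named here, three measured steps bear on this change, all of them changes on the same amide-type nitrogen: a step that the two limits leave unreadable from compound 1 to compound 2, a step that the two limits leave unreadable from compound 1 to compound 3 and a step that the two limits leave unreadable from compound 2 to compound 3. Going by the values given here, none has a size that can be read, so they provide no measured step to carry over to the new change. They show only that the three amide-type nitrogen groups tried so far all end at the limit in this assay. The expected outcome is therefore no step beyond the scatter, with a number no higher from compound 3 to compound 4 (the limit leaves the size open) as the estimated step. A reading at the limit is the most likely result, although a number somewhat lower cannot be excluded. For compound 4 the estimated value is 50000 nM, with an expected range from 20000 nM to 100000 nM.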

Compound 4, half-maximal effective concentration: > 50000 nM
Compound 4: a limit, no number; the forecaster's own chance of this, stated with the estimate: 70%; the middle value lies on the limit itself.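

In this assay compound 4 gives > 50000 nM, a limit and not a number. Its steps from compound 1, compound 2 and compound 3 cannot be read, and all four compounds share one position: the limit of > 50000 nM in this assay, at which 4 of the 4 values shown sit. The compounds shown leave open whether any group on the amide-type nitrogen of the shared core gives a measurable half-maximal effective concentration.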